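Ester in Place of Amine on a Bridged Bicyclic Core

The source may report more compounds than this note shows. Statements on the series, on what has been measured and on what is new or still open speak of the compounds shown alone.

Measured compounds:
Compound 1 `NC1CC2(N3CCCC3)CC(c3ccccc3)C1C(c1ccccc1)C2` gives 38100 nM in an ADME assay on L6 cells (Rattus norvegicus) for cytotoxicity, read by resazurin assay, with a stated time of 72 h; a lower number here means a stronger inhibitor, a higher number a weaker inhibitor.
Compound 2 `CN1CCN(CC(=O)OC2CC3(N4CCCC4)CC(c4ccccc4)C2C(c2ccccc2)C3)CC1` gives 24600 nM in this assay.
Compound 3 `NC1CC2(N3CCCCC3)CC(c3ccccc3)C1C(c1ccccc1)C2` gives 35000 nM in this assay.

All three compounds share a bridged bicyclic core carrying two phenyl groups, and they differ from one another at two sites. Compound 1 and compound 3 differ only in the amine ring attached to the core: piperidin-1-yl in place of pyrrolidin-1-yl on a saturated ring carbon That change gave a 1.1-fold lower number from compound 1 to compound 3 (0.04 log units; within the scatter), so the two values cannot be told apart.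

Compound 1 and compound 2 differ at the other site: (((4-methylpiperazin-1-yl)methyl)carbonyl)oxy in place of amino on a saturated ring carbon This exchange gave a 1.5-fold lower number from compound 1 to compound 2 (0.19 log units; within the scatter), again a small step.

Compound 4 `CN1CCN(CC(=O)OC2CC3(N4CCCCC4)CC(c4ccccc4)C2C(c2ccccc2)C3)CC1` has not yet been measured in this assay. It relates to compound 3 as compound 2 relates to compound 1: (((4-methylpiperazin-1-yl)methyl)carbonyl)oxy in place of amino on a saturated ring carbon The surroundings of the place are the same in the two pairs except that the ring atom two ring bonds away bears a piperidin-1-yl group in compound 3 rather than the pyrrolidin-1-yl group of compound 1, so this is the same kind of change, not the same change.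

Because compound 1 to compound 2 showed a 1.5-fold lower number from compound 1 to compound 2 (0.19 log units; within the scatter), the step from compound 3 to compound 4 is expected to be of similar small size, a 1.5-fold lower number from compound 3 to compound 4 (0.18 log units; within the scatter). Compound 4 is therefore estimated at 23000 nM in this assay, with a likely range from 10000 nM to 50000 nM. This rests on a single measured instance of the change, so the expectation carries real uncertainty.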

Compound 4, half-maximal inhibitory concentration: 29500 nM
Beside the measured number, compound 4's estimate is 1.3-fold (0.11 log units) below it, within the range that was stated.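

In this assay, putting (((4-methylpiperazin-1-yl)methyl)carbonyl)oxy in place of amino gave a 1.2-fold lower number from compound 3 to compound 4 (0.07 log units; within the scatter), and this step cannot be told apart from the one seen with the pyrrolidin-1-yl group on the shared core: the same change on two cores in this assay, a 1.5-fold lower number (0.19 log units; within the scatter) from compound 1 to compound 2 and a 1.2-fold lower number (0.07 log units; within the scatter) from compound 3 to compound 4, 1.3-fold (0.12 log units) apart, within the scatter of two such steps. The exchange of the amine ring, now seen a second time as a 1.2-fold higher number from compound 2 to compound 4 (0.08 log units; within the scatter), gives the same picture: the same change on two cores in this assay, a 1.1-fold lower number (0.04 log units; within the scatter) from compound 1 to compound 3 and a 1.2-fold higher number (0.08 log units; within the scatter) from compound 2 to compound 4, 1.3-fold (0.12 log units) apart, within the scatter of two such steps. Going by these compounds alone, both changes therefore stay too small to detect when carried from one core to the other, but this shows only that neither moves the number beyond the usual scatter in these four compounds; it does not show that a clear effect would carry over in the same way, and two instances of each change make no general rule.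

Every step here lies within the scatter, so the compounds shown leave open whether any group at these two sites can shift the number clearly in this assay. An amide in place of the ester link, a carboxylic acid or a longer chain on the saturated ring carbon, or a dimethylamino group in place of the amine ring, could test this.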